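The compounds below may be only part of what the source reports. "The series", "measured", "known", "first", "only" and "open" are said of these compounds alone.

Measured compounds:
compound 1 `O=C(Nc1ccc([Se][Se]c2ccc(NC(=O)OCc3ccccc3)cc2)cc1)OCc1ccccc1` — 100 nM
compound 2 `CCCCOC(=O)Nc1ccc([Se]C#N)cc1` — 5300 nM

Of the compounds shown here, two have been measured in an ADME assay on 184B5 cells (Homo sapiens) for cytotoxicity, read by MTT assay, with a stated time of 72 h; a lower number here means a stronger inhibitor of growth, a higher number a weaker inhibitor of growth. Compound 1 `O=C(Nc1ccc([Se][Se]c2ccc(NC(=O)OCc3ccccc3)cc2)cc1)OCc1ccccc1` gives 100 nM in this assay, while compound 2 `CCCCOC(=O)Nc1ccc([Se]C#N)cc1` gives 5300 nM. Compound 2 therefore stands at the highest of the two numbers; its nearest neighbour is compound 1, whose number is lower by an amount beyond the scatter. Among the compounds with values here, no step between two measured compounds that differ in one place is available, so the values of compound 1 and compound 2 can only be set side by side, not read as a step.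

Compound 3 `CCCCCCOC(=O)Nc1ccc([Se]C#N)cc1` has not yet been measured. It differs from compound 2 by ethyl in place of hydrogen on a saturated chain carbon, four bonds along the chain from an oxygen next to a carbonyl group. Within the data shown here, the measured set contains no pair that shows what such a lengthening of the chain does in this assay. Compound 3 is therefore expected to land close to compound 2, with a step of a 1.5-fold lower number from compound 2 to compound 3 (0.18 log units; within the scatter) that is expected to be small and, if anything, towards a lower number, but not clearly beyond the scatter. The estimate for compound 3 in this assay is 3500 nM, with a range from 1200 nM to 10000 nM.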

Compound 3, concentration for 50% growth inhibition: 4600 nM
The estimate for compound 3 lay 1.3-fold (0.12 log units) below the measured number; the range from low to high includes it.
By their numbers in this assay, from the lowest: compound 1; then compounds 3 and 2 (each within the scatter of the next).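

In this assay, ethyl in place of hydrogen on a saturated chain carbon, four bonds along the chain from an oxygen next to a carbonyl group, comes to a 1.2-fold lower number from compound 2 to compound 3 (0.06 log units; within the scatter). Within the data shown here, this is the first pair in the set that differs in one place, and it shows that this position takes the ethyl with no difference in the read-out that can be told from the scatter. No measurement of any other kind bears on this result, so the step stands without an explanation.

On these data alone, what a longer chain, or an amine or a carboxylic acid at the end of the chain, would do at this position stays open, as a single step says nothing about how far the flat reading extends. As far as these compounds go, compound 1 and compound 2 differ in more than one place, so which of those differences goes with the gap between their numbers also remains open, and compound 3 does not settle it.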